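This account rests on a few compounds, and the source may have more. Where it says the series, first, only, none or still open, it means among the compounds named here.

Values so far in a physicochemical assay for lipophilicity, read by HPLC, using the shake flask method (on this read-out lower numbers stand for lower lipophilicity and higher numbers for higher lipophilicity), are as follows.
- compound 1 `C/C(=N\C#N)N(Cc1ccccc1)Cc1ccc(Cl)nc1` gives 2.11
- compound 2 `CCCCC/C(=N\C#N)N(C)Cc1ccc(Cl)nc1` gives 2.3

Compound 1 and compound 2 lie within the usual scatter of each other, so these two numbers set no order. Compound 3 `CCN(Cc1ccc(Cl)nc1)/C(C)=N/C#N` is not yet measured. It differs from compound 1 by methyl in place of phenyl on a saturated chain carbon bound to an amine nitrogen. Among the measured compounds shown here, no measured pair shows this change, so the expectation rests on the structural change alone. In this assay a downward step beyond the scatter is expected, estimated as a number 0.81 log units lower from compound 1 to compound 3 (beyond the scatter) for now. For compound 3 the estimate is 1.3, with 0.95 to 1.65 as the expected range.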

Compound 3, partition coefficient: 1.19
Compound 3: middle estimate off by 0.11 log units, on the high side; the measured number falls inside the stated range.
By their numbers in this assay, from the lowest: compound 3; then compounds 1 and 2 (each within the scatter of the next).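

In this assay, among the compounds shown here, methyl in place of phenyl on a saturated chain carbon bound to an amine nitrogen brings a number 0.92 log units lower from compound 1 to compound 3 (beyond the scatter) and gives the series its only step between compounds that differ in one place. This place therefore has a readable effect on the number, which the two earlier values could not show. No measurement at hand bears on the cause of this step. The compounds shown leave open whether the step follows the loss of the aromatic ring or the loss of heavy atoms. A cyclohexyl group or a longer chain at this place would separate the two.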